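Methyl to hydrogen on the aromatic nitrogen, two cores

The source may hold more compounds than are shown below. What is called first, only, known or untested is meant among the compounds shown, and "the series" means these compounds.

Measured so far:
compound 1 `COc1cc(C(=O)NS(=O)(=O)c2ccccc2)ccc1Cc1cn(C)c2ccc(NC(=O)OC3CCCC3)cc12` gives 9.69 in an assay on isolated protein (Cavia porcellus) with cysteinyl leukotriene receptor (Homo sapiens) as the target; on this read-out higher numbers stand for higher potency (the scale is a negative logarithm) and lower numbers for lower potency
compound 2 `COc1cc(C(=O)NS(=O)(=O)c2ccccc2)ccc1Cc1c[nH]c2ccc(NC(=O)OC3CCCC3)cc12` gives 9.8
compound 3 `COc1cc(C(=O)O)ccc1Cc1cn(C)c2ccc(NC(=O)OC3CCCC3)cc12` gives 7.84

Compound 4 `COc1cc(C(=O)O)ccc1Cc1c[nH]c2ccc(NC(=O)OC3CCCC3)cc12` has not yet been measured in this assay. It differs from compound 3 by hydrogen in place of methyl on an aromatic nitrogen. The same change, (hydrogen in place of methyl on an aromatic nitrogen), separates compound 1 from compound 2, where it gave a number 0.11 log units higher from compound 1 to compound 2 (within the scatter). The two cores differ by hydroxy in place of (phenylsulfonyl)amino on a carbonyl carbon; that difference gave a number 1.85 log units lower from compound 1 to compound 3 (beyond the scatter), and compound 3 stands lowest of the three measured compounds. Whether the change carries over to the core of compound 3 rests on a single measured pair, and nothing among these compounds argues for a different outcome. For compound 4 the expected step is a number 0.11 log units higher from compound 3 to compound 4 (within the scatter), within the scatter, because a number 0.11 log units higher from compound 1 to compound 2 (within the scatter) was also within it. Compound 4 is therefore estimated at 7.95, with a range from 7.45 to 8.45.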

Compound 4, negative logarithm of the antagonist equilibrium constant: 7.32
The estimate for compound 4 lay 0.63 log units above the measured number; measured number outside the range, below it.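

In this assay hydrogen in place of methyl on an aromatic nitrogen gave a number 0.52 log units lower from compound 3 to compound 4 (beyond the scatter) and so did not carry over unchanged between the two cores: the same change on two cores in this assay, a number 0.11 log units higher (within the scatter) from compound 1 to compound 2 and a number 0.52 log units lower (beyond the scatter) from compound 3 to compound 4, 0.63 log units apart, beyond the scatter of two such steps.
Read the other way, hydroxy in place of (phenylsulfonyl)amino on a carbonyl carbon gave a number 2.48 log units lower from compound 2 to compound 4 (beyond the scatter) and also depended on the core: the same change on two cores in this assay, a number 1.85 log units lower (beyond the scatter) from compound 1 to compound 3 and a number 2.48 log units lower (beyond the scatter) from compound 2 to compound 4, 0.63 log units apart, beyond the scatter of two such steps.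
These four compounds show that the two changes do not act independently here, but they do not show why, and they give no direction for the methyl change on any further core.

Open, from the compounds shown here alone, is whether an ethyl group on the aromatic nitrogen follows the step seen on the core of compound 1 or the one seen on the core of compound 3. Also open, going by these compounds, is how an amino group on the carbonyl carbon would behave with either methyl or hydrogen on that nitrogen.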